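The source may report more compounds than this note shows. Statements on the series, on what has been measured and on what is new or still open speak of the compounds shown alone.

Compounds measured in an ADME assay on BV-2 cells (Mus musculus) for cytotoxicity, with a stated time of 24 h, tested at 10 uM; a higher number here means a weaker effect of the compound at the concentration tested, a lower number a stronger effect:

Compound 1, `COc1ccccc1S(=O)(=O)/C=C/c1ccccn1`, gives 100%.
Compound 2, `COc1cccc(S(=O)(=O)/C=C/c2ccccn2)c1`, gives 100%.
Compound 3, `COc1ccccc1S(=O)(=O)/C=C/c1cccnc1`, gives 100%.

Going by the values given here, all three values in this assay stand level within the scatter, so no compound is set apart from the others. The change from compound 1 to compound 3 is pyridin-3-yl in place of pyridin-2-yl on a double-bonded chain carbon bound to a double-bonded chain carbon, and it made the step of no change at the digits printed from compound 1 to compound 3 (within the scatter). The difference between the core of compound 1 and the core of compound 2 is not broken down here; their two values show no difference within the scatter.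

Compound 4, `COc1cccc(S(=O)(=O)/C=C/c2cccnc2)c1`, has not yet been measured in this assay. It differs from compound 2 by pyridin-3-yl in place of pyridin-2-yl on a double-bonded chain carbon bound to a double-bonded chain carbon, the same change, at the same place, as that from compound 1 to compound 3. For compound 4 a step of no change at the digits printed from compound 2 to compound 4 (within the scatter) is expected, resting on the step of no change at the digits printed from compound 1 to compound 3 (within the scatter) seen for the same change. Compound 4 is therefore estimated at 100% in this assay, between 90% and 100%.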

Compound 4, a percentage reported as activity, at one concentration (the size of the read-out at that concentration, not a potency): 100%
The estimate for compound 4 equals the measured number at the digits printed, and the stated range covers the measured number.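

In this assay, pyridin-3-yl in place of pyridin-2-yl gave no change at the digits printed from compound 2 to compound 4 (within the scatter), so the change behaved alike on the two cores: the same change on two cores in this assay, no change at the digits printed (within the scatter) from compound 1 to compound 3 and no change at the digits printed (within the scatter) from compound 2 to compound 4, 0 percentage points apart, within the scatter of two such steps

This shows that, in this small set, the change carried from the core of compound 1 to the core of compound 2 without altering the read-out. It does not show that the change is without effect in general, since both steps are null results from a read-out at a single concentration, and two cores cannot establish a rule for the series.

Going by these compounds, whether an amine or a carboxylic acid on either core would move the read-out away from the level of these four compounds remains open. So does the effect of a longer chain between the two rings.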